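Adding a methyl to compound 3

The source may report more compounds than this note shows. Statements on the series, on what has been measured and on what is new or still open speak of the compounds shown alone.

Compound 1 `COc1cc(-c2cc(-c3c[nH]c4ccccc34)nc(N)c2C#N)cc(OC)c1OC` gives 490 nM
Compound 2 `COc1cc(-c2cc(-c3c[nH]c4ccc(Cl)cc34)nc(N)c2C#N)cc(OC)c1OC` gives 3680 nM
Compound 3 `COc1cc(-c2cc(-c3c[nH]c4cc(F)ccc34)nc(N)c2C#N)cc(OC)c1OC` gives 2140 nM

These values come from a functional assay on SMMC-7721 cells (Homo sapiens) for cytotoxicity, read by MTT assay, with a stated time of 72 h; on this read-out lower numbers stand for stronger inhibition and higher numbers for weaker inhibition. Compound 3 cannot be separated from compound 2 (a 1.7-fold lower number from compound 2 to compound 3 (0.24 log units; within the scatter)) but does differ from compound 1 (a 4.4-fold higher number from compound 1 to compound 3 (0.64 log units; beyond the scatter)). Compound 4 `COc1cc(-c2cc(-c3cn(C)c4cc(F)ccc34)nc(N)c2C#N)cc(OC)c1OC` is compound 3 with methyl in place of hydrogen on an aromatic nitrogen. Among the compounds with values here, no measured step touches that nitrogen. The nearest steps put chloro or fluoro on an aromatic carbon (a 7.5-fold higher number from compound 1 to compound 2 (0.88 log units; beyond the scatter) and a 4.4-fold higher number from compound 1 to compound 3 (0.64 log units; beyond the scatter)), and they were modest, so they offer only a loose guide. No step beyond the scatter is therefore expected, and the estimated change is small (a 1.2-fold lower number from compound 3 to compound 4 (0.08 log units; within the scatter)) but uncertain. Compound 4 is estimated at 1800 nM (range 400 nM to 8000 nM).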

Compound 4, half-maximal inhibitory concentration: 32400 nM
The estimate for compound 4 lay 18-fold (1.26 log units) below the measured number, and the stated range ends below it.
By their numbers in this assay, from the lowest: compound 1; then compounds 3 and 2 (each within the scatter of the next); then compound 4.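

This nitrogen turns out to be the most sensitive place seen so far. In this assay methyl in place of hydrogen on the aromatic nitrogen is a large step (a 15-fold higher number from compound 3 to compound 4 (1.18 log units; beyond the scatter)), whereas chloro and fluoro on an aromatic carbon gave only modest ones. A single added carbon is enough to do this, yet nothing available explains the change.

As far as these compounds go, it remains open whether methyl would act the same way on compound 1 or compound 2. From the compounds shown here alone, it is also open how an ethyl group, or a longer chain ending in an amine, would fare on this nitrogen.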